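The source may report more compounds than this note shows. Statements on the series, on what has been measured and on what is new or still open speak of the compounds shown alone.

Measured in a functional assay on P388 cells (Mus musculus); on this read-out higher numbers stand for weaker inhibition and lower numbers for stronger inhibition:
- compound 1 `Cc1ccc(/C=C/C(=O)Oc2ccc(/C=C3\CCCCC3=O)cc2)cc1`: > 50000 nM, a limit
- compound 2 `O=C(/C=C/c1ccc(F)cc1)Oc1ccc(/C=C2\CCCCC2=O)cc1`: > 50000 nM, a limit
- compound 3 `Cc1ccc(/C=C/C(=O)Oc2ccc(/C=C3\CCCC(CN(C)C)C3=O)cc2)cc1`: 1290 nM

Among the compounds with values here, compound 3 is the only compound here with a true number. The other two stand at the limit of > 50000 nM in this assay, at which 2 of the 3 values shown sit. The (dimethylamino)methyl group accompanies an at least 38-fold lower number from compound 1 to compound 3 (1.58 log units; beyond the scatter).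

Next is compound 4 `CN(C)CC1CCC/C(=C\c2ccc(OC(=O)/C=C/c3ccc(Br)cc3)cc2)C1=O`, with bromo in place of methyl on an aromatic carbon, para to a large group: bromo in place of methyl on an aromatic carbon. The closest measured exchange, fluoro in place of methyl, is a step that the two limits leave unreadable from compound 1 to compound 2, so it gives no size. The large step lies at another place, and compound 4 keeps that group. In this assay, no change beyond the scatter is therefore expected, and the estimate is a 1.1-fold lower number from compound 3 to compound 4 (0.03 log units; within the scatter). For compound 4 the estimated value is 1200 nM, with an expected range of 400 nM to 3600 nM.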

Compound 4, half-maximal inhibitory concentration: 4030 nM
For compound 4 the middle estimate is 3.4-fold (0.53 log units) below the measured one; the measured number lies above the stated range.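

With the (dimethylamino)methyl group kept, the aromatic position gives its first readable step in this assay: bromo in place of methyl is a 3.1-fold higher number from compound 3 to compound 4 (0.49 log units; beyond the scatter). The exchange at this position therefore moves the number, though modestly beside an at least 38-fold lower number from compound 1 to compound 3 (1.58 log units; beyond the scatter). The fluoro exchange on the core without that group cannot be read: the limit of > 50000 nM in this assay, at which 2 of the 4 values shown sit.

Still open, from the compounds shown here alone, is how fluoro, chloro or methoxy at this position would read with the (dimethylamino)methyl group in place. Also open, going by these compounds, is whether the bromo step carries over when a piperidinylmethyl group replaces that group.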